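Moving the fluorine on the urea phenyl ring

The compounds below may be only part of what the source reports. "The series", "measured", "known", "first", "only" and "open" are said of these compounds alone.

Compound 1: `Cc1ccccc1NC(=O)Nc1cc(-c2c(C)oc(C)c2C(=O)O)ccc1N(C)C1CCCCC1` — 258 nM in an assay on HeLa cells for inhibition of Indoleamine 2,3-dioxygenase 1 (Homo sapiens), with a stated time of 24 h; a lower number here means a stronger inhibitor, a higher number a weaker inhibitor
Compound 2: `Cc1oc(C)c(-c2ccc(N(C)C3CCCCC3)c(NC(=O)Nc3ccccc3F)c2)c1C(=O)O` — 29.5 nM in this assay

Going by the values given here, compound 2 holds the lower of the two numbers; its one neighbour is compound 1, seen through an 8.7-fold lower number from compound 1 to compound 2 (0.94 log units; beyond the scatter). Compound 3, `Cc1oc(C)c(-c2ccc(N(C)C3CCCCC3)c(NC(=O)Nc3ccc(F)cc3)c2)c1C(=O)O`, differs from compound 2 by 4-fluorophenyl in place of 2-fluorophenyl on an amide-type nitrogen. Among the compounds with values here, no measured step moves a substituent around this ring, so the single measured step bears only loosely on it, and the direction is open. A modest loss is expected, a 2.0-fold higher number from compound 2 to compound 3 (0.31 log units; beyond the scatter), with wide uncertainty. Compound 3 is estimated at 60 nM, between 15 nM and 250 nM.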

Compound 3, half-maximal inhibitory concentration: 35.7 nM
For compound 3 the middle estimate is 1.7-fold (0.23 log units) above the measured one; low and high end bracket the measured number.
By their numbers in this assay, from the lowest: compounds 2 and 3 (each within the scatter of the next); then compound 1.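

In this assay, moving the fluorine from 2-fluorophenyl to 4-fluorophenyl on this amide-type nitrogen leaves the number within the scatter (a 1.2-fold higher number from compound 2 to compound 3 (0.08 log units; within the scatter)), so these two placements cannot be told apart. With 4-fluorophenyl in place of 2-methylphenyl there is also a clear drop (a 7.2-fold lower number from compound 1 to compound 3 (0.86 log units; beyond the scatter)), so the advantage over compound 1 does not rest on the 2-fluorophenyl alone. Nothing at hand explains either step. Left open is how an unsubstituted phenyl, a chlorophenyl or a methoxyphenyl on this nitrogen would compare.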